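Carboxy in Place of Trifluoromethyl: An Untested Step

This account rests on a few compounds, and the source may have more. Where it says the series, first, only, none or still open, it means among the compounds named here.

Compound 1, `COc1ccc(-n2nc(C(=O)Nc3cccc(F)c3)nc2-c2cc(OC)c(OC)c(OC)c2)cc1`, gives 53% in a functional assay on the whole organism for inhibition, with Rattus norvegicus as the target, read by paw edema, with stated times of 30 min and 5 h, at a dose of 0.28 mmol/kg by the oral route; a higher number here means more inhibition at the dose given (going by the name of the read-out), a lower number less inhibition.
Compound 2, `COc1ccc(-n2nc(C(=O)Nc3ccc(C(F)(F)F)cc3)nc2-c2cc(OC)c(OC)c(OC)c2)cc1`, gives 50%.

Compound 2 sits alongside compound 1: the step of a number 3 percentage points lower from compound 1 to compound 2 (within the scatter) is within the scatter, so the two numbers cannot be told apart. Compound 3, `COc1ccc(-n2nc(C(=O)Nc3ccc(C(=O)O)cc3)nc2-c2cc(OC)c(OC)c(OC)c2)cc1`, differs from compound 2 by carboxy in place of trifluoromethyl on an aromatic carbon. No measured step bears on a carboxy group here; the only step shown, a number 3 percentage points lower from compound 1 to compound 2 (within the scatter), concerns a different exchange and is itself within the scatter. With nothing to lean on, the change is expected to be a number 5 percentage points lower from compound 2 to compound 3 (within the scatter), no more than the scatter. Compound 3 is estimated at 45%, between 22% and 66%.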

Compound 3, a percentage reported as inhibition, in the whole organism at one dose (the size of the read-out at that dose, not a potency): 60%
The estimate for compound 3 lay 15 percentage points below the measured number; low and high end bracket the measured number.
By their numbers in this assay, from the lowest: compounds 2, 1 and 3 (each within the scatter of the next).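

Carboxy in place of trifluoromethyl on this aromatic carbon gives a number 10 percentage points higher from compound 2 to compound 3 (within the scatter) in this assay and shows that a group carrying a hydrogen-bond donor and acceptor can stand here without a change beyond the scatter. The step with 4-carboxyphenyl in place of 3-fluorophenyl reads a number 7 percentage points higher from compound 1 to compound 3 (within the scatter) and so these two amide substituents cannot be told apart either. Nothing available explains this result.

Going by these compounds, whether an amine or a methyl ester at this same place would give a similar number remains open.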